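Bromine added to the hydroxyphenyl ring of compound 2

The compounds below may be only part of what the source reports. "The series", "measured", "known", "first", "only" and "open" are said of these compounds alone.

Compound 1 `CC1=NN(C(=O)c2ccc([N+](=O)[O-])cc2)C(c2ccccc2O)C1`: 30100 nM
Compound 2 `CC1=NN(C(=O)COc2ccc(Cl)cc2)C(c2ccccc2O)C1`: "not active" (no number reported)

Both compounds were tested in a functional assay on HepG2 cells (Homo sapiens) for cytotoxicity, read by MTT assay, with a stated time of 48 h; on this read-out higher numbers stand for weaker inhibition and lower numbers for stronger inhibition. Compound 1 gives 30100 nM. Compound 2 stands apart, since for it the read-out was recorded only as "not active" (no number reported), without a number; on the numbers shown it therefore cannot be placed on the scale at all, and nothing can be said of how far it lies from compound 1.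

Compound 3 `CC1=NN(C(=O)COc2ccc(Cl)cc2)C(c2cc(Br)ccc2O)C1` differs from compound 2 in one place: bromo in place of hydrogen on an aromatic carbon, that is, on an aromatic carbon of a six-membered aromatic ring of carbon only, para to a hydroxy group. Among the measured compounds shown here, no step between measured compounds exists that would tell the size of such a change in this assay. With compound 2 giving no number, the expectation for compound 3 rests only on compound 1 giving 30100 nM as the one numeric point, and a weak result is expected here as well, with a real chance that again no number is returned. Compound 3 is estimated at 50000 nM, expected to fall between 12000 nM and 200000 nM.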

Compound 3, half-maximal inhibitory concentration: "not active" (no number reported)
For compound 3 the study gives words and no number; no gap can be computed for the estimate.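

In this assay compound 2 gives "not active" (no number reported) and compound 3 gives "not active" (no number reported), so no step can be read between them. The compounds shown leave open what bromo in place of hydrogen does to a measurable value in this assay. Nothing at hand bears on this result.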